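Enlarging the Ring on the Aminoacyl Group

This account rests on a few compounds, and the source may have more. Where it says the series, first, only, none or still open, it means among the compounds named here.

Measured so far in a functional assay on U-87MG ATCC cells (Homo sapiens) for antiproliferative activity (on this read-out lower numbers stand for stronger inhibition and higher numbers for weaker inhibition), and shown here for each compound:

- compound 1 `Cc1c2c(n3c1CCN(C(=O)CN)C[C@@H](C)[C@H](C)Nc1cc-3ccc1C(N)=O)CC(C)(C)CC2=O` gives 378 nM
- compound 2 `Cc1c2c(n3c1CCN(C(=O)[C@@H](N)C(C)C)C[C@@H](C)[C@H](C)Nc1cc-3ccc1C(N)=O)CC(C)(C)CC2=O` gives 48 nM
- compound 3 `Cc1c2c(n3c1CCN(C(=O)C1(N)CC1)C[C@@H](C)[C@H](C)Nc1cc-3ccc1C(N)=O)CC(C)(C)CC2=O` gives 85 nM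

Compound 3 stands level with compound 2 within the scatter, as the comparison shows: a 1.8-fold higher number from compound 2 to compound 3 (0.25 log units; within the scatter) and that gap should not be read as a real difference. Both compounds sit clearly under compound 1 (378 nM).

Compound 4 `Cc1c2c(n3c1CCN(C(=O)C1(N)CCCC1)C[C@@H](C)[C@H](C)Nc1cc-3ccc1C(N)=O)CC(C)(C)CC2=O` has 1-aminocyclopentyl in place of 1-aminocyclopropyl on a carbonyl carbon, and the other neighbour of that carbon is an amide-type nitrogen in a ring 1-aminocyclopentyl in place of 1-aminocyclopropyl on a carbonyl carbon and the rest of the molecule stays the same.

Two measured steps add carbon to the simple aminomethyl group, and both lowered the number: a 7.9-fold lower number from compound 1 to compound 2 (0.90 log units; beyond the scatter) for the isopropyl group and a 4.4-fold lower number from compound 1 to compound 3 (0.65 log units; beyond the scatter) for the cyclopropane ring. Neither step enlarges a ring, so the data offer only indirect guidance. With two different additions landing close together, a further large change seems unlikely. The expected result is a 1.4-fold lower number from compound 3 to compound 4 (0.15 log units; within the scatter) and this estimate leans slightly downward without leaving the scatter. For compound 4 the estimated value is 60 nM with an expected range from 22 nM to 170 nM in this assay as the read-out.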

Compound 4, half-maximal inhibitory concentration: 44 nM
Estimate against measurement, compound 4: 1.4-fold (0.13 log units) above; the measured number falls inside the stated range.
By their numbers in this assay, from the lowest: compounds 4, 2 and 3 (each within the scatter of the next); then compound 1.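

Moving from a three-membered to a five-membered ring on this carbonyl carbon leaves the read-out in this assay level (a 1.9-fold lower number from compound 3 to compound 4 (0.29 log units; within the scatter)), so 1-aminocyclopentyl is accepted here as readily as 1-aminocyclopropyl. Compound 4 also stands level with the branched open-chain group of compound 2 (a 1.1-fold lower number from compound 2 to compound 4 (0.04 log units; within the scatter)), while it keeps a clear advantage over the plain aminomethyl group (an 8.6-fold lower number from compound 1 to compound 4 (0.93 log units; beyond the scatter)); among the compounds shown, the large separation is therefore between compound 1 and the other three, and the branched chain and the two rings cannot be told apart. No available measurement explains why these three groups give such similar results.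

Going by these compounds, it remains open whether the same level holds for a still larger carbon ring, such as 1-aminocyclohexyl, or for a ring containing oxygen, such as 4-aminotetrahydropyran-4-yl. The compounds shown also leave open what happens when the free amine on this ring is replaced, for example by a dimethylamino group or a hydroxyl group.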